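Swapping a cyclohexyl for a dimethylcarbamoyl group

The source may hold more compounds than are shown below. What is called first, only, known or untested is meant among the compounds shown, and "the series" means these compounds.

Measured so far:
Compound 1, `Cn1cc(-c2ccc(NC(=O)c3cn(CC4CCCCC4)cc(-c4ccc(F)cc4)c3=O)cc2)c2c(N)ncnc21`, 2.3 nM
Compound 2, `Nc1ncnc2[nH]cc(-c3cc(F)c(NC(=O)c4cn(CC5CCOCC5)cc(-c5ccc(F)cc5)c4=O)cc3F)c12`, 0.4 nM

In an assay on isolated protein for inhibition of tyrosine-protein kinase receptor UFO (Homo sapiens), read by ELISA (a lower number here means a stronger inhibitor, a higher number a weaker inhibitor), compound 1 gives 2.3 nM, the highest of the two numbers; compound 2 gives 0.4 nM, a lower number that lies beyond the usual scatter. Compound 3, `CN(C)C(=O)Cn1cc(C(=O)Nc2ccc(-c3cn(C)c4ncnc(N)c34)cc2)c(=O)c(-c2ccc(F)cc2)c1`, has not been measured. It differs from compound 1 in one place: dimethylcarbamoyl in place of cyclohexyl on a saturated chain carbon bound to an aromatic nitrogen. Among the measured compounds shown here, no measured pair shows this change, so only a modest step is expected in this assay, toward a slightly higher number. Compound 3 is therefore estimated at 5 nM, between 1.5 nM and 20 nM, a step of a 2.2-fold higher number from compound 1 to compound 3 (0.34 log units; beyond the scatter) expected.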

Compound 3, half-maximal inhibitory concentration: 0.5 nM
The estimate for compound 3 lay 10-fold (1.00 log units) above the measured number, and the stated range ends above it.
By their numbers in this assay, from the lowest: compounds 2 and 3 (each within the scatter of the next); then compound 1.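

Replacing cyclohexyl with dimethylcarbamoyl in this assay gives a 4.6-fold lower number from compound 1 to compound 3 (0.66 log units; beyond the scatter) and shows that a carbon-only ring is not required at this place for strong inhibition. The change removes that ring and adds a hydrogen-bond acceptor, yet the number still falls. Nothing measured here explains the gain.

From the compounds shown here alone, it remains open whether the whole dimethylcarbamoyl group matters or only part of it. A primary amide, a carboxylic acid or a dimethylamino group on the same chain could begin to separate those parts.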